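The source may hold more compounds than are shown below. What is called first, only, known or untested is meant among the compounds shown, and "the series" means these compounds.

Measured compounds in an ADME assay on MT4 cells (Homo sapiens) for cytotoxicity, read by MTT assay, with a stated time of 5 days; a higher number here means that more compound is tolerated, a lower number that less compound is tolerated:
Compound 1 `Cc1cc(C)c(Oc2cc(Nc3ccc(C#N)cc3)ncc2C(=O)NCc2cn(Cc3ccccc3[N+](=O)[O-])nn2)c(C)c1` gives > 212000 nM, which is a limit of the assay and not a number.
Compound 2 `Cc1cc(C)c(Oc2cc(Nc3ccc(C#N)cc3)ncc2C(=O)NCc2cn(Cc3ccc(F)cc3)nn2)c(C)c1` gives >= 153000 nM, again a limit of the assay.
Compound 3 `Cc1cc(C)c(Oc2cc(Nc3ccc(C#N)cc3)ncc2C(=O)NCc2cn(Cc3ccc(Cl)cc3)nn2)c(C)c1` gives >= 120000 nM, also a limit of the assay.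

Compound 3 thus stands only at a limit, and the two other values shown are limits as well. The steps a step that the two limits leave unreadable from compound 1 to compound 2, a step that the two limits leave unreadable from compound 1 to compound 3 and a step that the two limits leave unreadable from compound 2 to compound 3 cannot be read in size, since each pair sits at two limits. Compound 4 `Cc1cc(C)c(Oc2cc(Nc3ccc(C#N)cc3)ncc2C(=O)NCc2cn(Cc3cccc([N+](=O)[O-])c3)nn2)c(C)c1` differs from compound 3 by 3-nitrophenyl in place of 4-chlorophenyl on a saturated chain carbon bound to an aromatic nitrogen. Among the compounds with values here, none of the measured steps gives a readable size or direction for this change, so no step beyond the scatter in this assay is expected, and most likely a limit is reported again. Compound 4 is expected at 150000 nM, between 60000 nM and 300000 nM. The expected step is a step that the limit leaves unreadable from compound 3 to compound 4.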

Compound 4, half-maximal cytotoxic concentration: >= 156000 nM
Compound 4 ended at the assay's limit; the forecaster's own chance of this, stated with the estimate: 85%; middle value at least 1.0-fold (0.01 log units) from the limit.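

Compound 4, like compound 1, compound 2 and compound 3, stands only at a limit, and its steps to those three cannot be read in size. The compounds shown leave open where each true half-maximal cytotoxic concentration lies, and whether exchanging these groups shifts it at all.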